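Series notes: the step from compound 3 to compound 4

A few compounds are considered here, and "the series" means these few. Any claim that something is new, unique, unknown or untested is made for them only; others in the source may bear on it.

Measured so far in a functional assay on the whole organism (strain Wistar) for inhibition, with Rattus norvegicus as the target, read by paw edema, with stated times of 2 h and 1 h, at a dose of 6 mg/kg by the oral route; a higher number here means more inhibition at the dose given (going by the name of the read-out), a lower number less inhibition:
compound 1 `O=C(CO[N+](=O)[O-])NNC(=O)c1ccc(-n2[nH]c(=O)cc2-c2ccc([N+](=O)[O-])cc2)cc1` gives 27.1%
compound 2 `COc1ccccc1-c1cc(=O)[nH]n1-c1ccc(C(=O)NNC(=O)CO[N+](=O)[O-])cc1` gives 55.7%
compound 3 `CCOC(=O)c1c(-c2ccccc2OC)n(-c2ccc(C(=O)NNC(=O)CO[N+](=O)[O-])cc2)[nH]c1=O` gives 30.7%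

Compound 3 sits below compound 2 by a number 25 percentage points lower from compound 2 to compound 3 (beyond the scatter), and its value lies within the scatter of compound 1, so no order between those two is claimed. Within the data shown here, the only other step, a number 28.6 percentage points higher from compound 1 to compound 2 (beyond the scatter), alters the aryl group on the shared core and shows that this position can move the read-out substantially.

Compound 4 `CCOC(=O)c1c(-c2ccccc2)n(-c2ccc(C(=O)NNC(=O)CO[N+](=O)[O-])cc2)[nH]c1=O` differs from compound 3 by hydrogen in place of methoxy on an aromatic carbon; cut one bond further out, the same difference reads 2-methoxyphenyl to phenyl. Among the measured compounds shown here, no measured step removes the methoxy group on its own. The step from compound 1 to compound 2 concerns the same ring but swaps one substituted phenyl for another, a larger change than a single methoxy to hydrogen, so it bears only loosely. Both informative steps were modest in size. The expectation is therefore a small downward move in this assay, quite possibly within the scatter, with no strong basis for a large shift either way.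

For compound 4 the estimate is 26%, with a range from 12% to 42%. For compound 4 this is expected to mean a number 4.7 percentage points lower from compound 3 to compound 4 (within the scatter).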

Compound 4, a percentage reported as inhibition, in the whole organism at one dose (the size of the read-out at that dose, not a potency): 57.8%
Compound 4: middle estimate off by 31.8 percentage points, on the low side; the whole stated range lies below it.
By their numbers in this assay, from the lowest: compounds 1 and 3 (each within the scatter of the next); then compounds 2 and 4 (each within the scatter of the next).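

In this assay, removing the methoxy group alone while ethoxycarbonyl stays in place gives a number 27.1 percentage points higher from compound 3 to compound 4 (beyond the scatter), so a change of 2 heavy atoms on this aromatic carbon is enough to move the read-out beyond the scatter. This also alters how a number 25 percentage points lower from compound 2 to compound 3 (beyond the scatter) reads: that drop was seen only with 2-methoxyphenyl on the shared core, whereas compound 4, which pairs ethoxycarbonyl with phenyl, gives 57.8%, so ethoxycarbonyl does not go with a low number in every compound shown. Nothing available here accounts for the size of this step, and no supporting data bear on it.

Whether the low number of compound 3 belongs to the methoxy group as such or to its pairing with ethoxycarbonyl stays open, as the effect of ethoxycarbonyl alongside phenyl cannot be read from the compounds shown. Also open, going by these compounds, is how the read-out would respond to a hydroxy group or an amine in place of methoxy, or to a carboxylic acid in place of ethoxycarbonyl.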